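The source may hold more compounds than are shown below. What is called first, only, known or untested is meant among the compounds shown, and "the series" means these compounds.

Measured so far in a functional assay on the whole organism (spleen, spleen, strain LEW) for inhibition, with Rattus norvegicus as the target, with a stated time of 4 days; on this read-out lower numbers stand for an effect already at smaller amounts and higher numbers for an effect only at larger amounts of compound
- compound 1 `CCc1cc(CN2CC(C(=O)O)C2)sc1-c1ncc(-c2ccc(OC(C)C)c(C)c2)s1` gives 0.07 mg/kg
- compound 2 `CCc1cc(-c2cnc(-c3sc(CN4CC(C(=O)O)C4)cc3CC)s2)ccc1OC(C)C` gives 0.16 mg/kg
- compound 3 `CCc1nc(CN2CC(C(=O)O)C2)ccc1-c1cnc(-c2ccc(CC(C)C)c(C)c2)s1` gives 0.64 mg/kg

Compound 3 (0.64 mg/kg) has the highest number of the three, and the gaps to compound 2 and compound 1 both lie beyond the scatter. Compound 4 `CCc1cc(-c2ncc(-c3ccc(CN4CC(C(=O)O)C4)nc3CC)s2)ccc1CC(C)C` has not yet been measured. The difference from compound 3 is methyl in place of hydrogen on a saturated chain carbon bound to an aromatic carbon (methyl in place of hydrogen on a saturated chain carbon bound to an aromatic carbon, or methyl to ethyl). Within the data shown here, only one measured step shows the same change (a 2.3-fold higher number from compound 1 to compound 2 (0.36 log units; beyond the scatter)), and it is modest. This single pair has a different structure from compound 3 elsewhere, so it offers only a rough guide to direction and size. A similarly modest move towards a higher number is therefore expected in this assay, although a smaller step cannot be excluded. The expected change is (a 2.0-fold higher number from compound 3 to compound 4 (0.31 log units; beyond the scatter)). Compound 4 is estimated at 1.3 mg/kg (expected range 0.45 mg/kg to 3.6 mg/kg).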

Compound 4, dose for 50% inhibition: 0.74 mg/kg
Compound 4: middle estimate off by 1.8-fold (0.24 log units), on the high side; the range from low to high includes it.
By their numbers in this assay, from the lowest: compound 1; then compound 2; then compounds 3 and 4 (each within the scatter of the next).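

In this assay, methyl in place of hydrogen on a saturated chain carbon bound to an aromatic carbon gives a 1.2-fold higher number from compound 3 to compound 4 (0.06 log units; within the scatter), so on this second core the change produces no step beyond the scatter. Among these compounds, the earlier pair alone pointed to a modest rise in the number, and that direction no longer holds as a general reading for this position, since only the step on the core of compound 1 lies beyond the scatter. Even so, the two steps cannot be told apart: the same change on two cores in this assay, a 2.3-fold higher number (0.36 log units; beyond the scatter) from compound 1 to compound 2 and a 1.2-fold higher number (0.06 log units; within the scatter) from compound 3 to compound 4, 2.0-fold (0.30 log units) apart, within the scatter of two such steps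

What the compounds shown leave open is how a longer chain such as propyl or butyl, or a hydroxymethyl group, would read at this same place. Going by these compounds, with one pair on each core, it also stays open whether the size of this step depends on the core at all.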